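Estimating compound 3 from one earlier ester swap

This account rests on a few compounds, and the source may have more. Where it says the series, first, only, none or still open, it means among the compounds named here.

Measured in a functional assay, read by spectrophotometry, with a stated time of 30 min; a higher number here means that more compound is needed for the effect, a lower number that less compound is needed 
- Compound 1 `COc1ccc(C(=O)OCC2Oc3ccc([C@H]4Oc5cc(O)cc(O)c5C(=O)[C@@H]4O)cc3OC2c2ccc(O)c(OC)c2)cc1` gives 73300 nM 
- Compound 2 `COc1cc(C2Oc3cc([C@H]4Oc5cc(O)cc(O)c5C(=O)[C@@H]4O)ccc3OC2COC(=O)c2cccc(Cl)c2)ccc1O` gives 106000 nM 

Compound 2 lies within the scatter of compound 1, so the two cannot be ranked. Compound 3 `COc1cc(C2Oc3cc([C@H]4Oc5cc(O)cc(O)c5C(=O)[C@@H]4O)ccc3OC2COC(=O)/C=C/c2ccc(Cl)cc2)ccc1O` carries 2-(4-chlorophenyl)ethenyl in place of 3-chlorophenyl on a carbonyl carbon. Within the data shown here, the only measured guide is a swap at that same carbonyl carbon, a 1.4-fold higher number from compound 1 to compound 2 (0.16 log units; within the scatter). With just this one small step to go on, no change beyond the scatter is expected in this assay, and no direction is favoured. The estimated step is a 1.1-fold lower number from compound 2 to compound 3 (0.03 log units; within the scatter). Compound 3 is expected near 100000 nM, with an estimated range from 45000 nM to 220000 nM.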

Compound 3, half-maximal effective concentration: 87900 nM
Compound 3: the middle estimate sits 1.1-fold (0.06 log units) above what was measured; the measured number falls inside the stated range.
By their numbers in this assay, from the lowest: compounds 1, 3 and 2 (each within the scatter of the next).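

In this assay, 2-(4-chlorophenyl)ethenyl, which adds a double bond outside the aromatic ring, stays within the scatter of both earlier esters (a 1.2-fold lower number from compound 2 to compound 3 (0.08 log units; within the scatter)) and (a 1.2-fold higher number from compound 1 to compound 3 (0.08 log units; within the scatter)). All three groups on this carbonyl carbon therefore give numbers that cannot be ranked, even though the new group is larger and carries its chlorine on a different position name. No measurement at hand offers a reason for this. Still open, on these data alone, is whether an amine or a carboxylic acid at this carbonyl carbon would give a step beyond the scatter.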